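A few compounds are considered here, and "the series" means these few. Any claim that something is new, unique, unknown or untested is made for them only; others in the source may bear on it.

Going by the values given here, the series so far holds three measured compounds. In a functional assay on KB cells (Homo sapiens) for antiproliferative activity, read by sulforhodamine B assay, with a stated time of 72 h (on this read-out higher numbers stand for weaker inhibition and lower numbers for stronger inhibition), compound 1 `COc1ccc(O)c(C(=O)/C=C/c2csc3ccccc23)c1` gives 640 nM and compound 2 `CC(C)Oc1ccc(O)c(C(=O)/C=C/c2csc3ccccc23)c1` gives 10000 nM. Compound 3 `O=C(/C=C/c1cc2ccccc2s1)c1cc(Cl)ccc1O` has no number, only a limit of the assay at > 10000 nM.

Compound 4 `O=C(/C=C/c1cc2ccccc2s1)c1cc(Br)ccc1O` differs from compound 3 in one place, bromo in place of chloro on an aromatic carbon, para to a hydroxy group.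

Among the compounds with values here, the only measured step is a 16-fold higher number from compound 1 to compound 2 (1.19 log units; beyond the scatter), with isopropyl in place of methyl on an oxygen on an aromatic ring. That step is large, but it changes a different group on a core that is not the core of compound 3, so it bears on this change only loosely. Within the data shown here, it shows that one group can move the read-out, but no measured pair exchanges one halogen for another.

Compound 3 sets the starting point with its limit of > 10000 nM, so compound 4 is expected to remain weak. The expected step is a step that the limit leaves unreadable from compound 3 to compound 4, which means none beyond the scatter and no favoured direction. Compound 4 is estimated at 12000 nM, within an expected range of 5000 nM to 30000 nM.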

Compound 4, half-maximal inhibitory concentration: > 10000 nM
Compound 4 was reported as a limit; the forecaster's own chance of this, stated with the estimate: 75%; the middle value is on the limit's open side.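

Compound 3 and compound 4 both stand only as limits in this assay, so no step can be read for bromo in place of chloro on an aromatic carbon: the limit of > 10000 nM in this assay, at which 2 of the 4 values shown sit.

The compounds shown leave open how far compound 3 and compound 4 lie from that limit, and whether this exchange moves the read-out at all.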